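The source may report more compounds than this note shows. Statements on the series, on what has been measured and on what is new or still open speak of the compounds shown alone.

Measured compounds:
Compound 1, `CC(c1ccc2oc(-c3ccccc3)cc2c1)N(O)C(=O)c1cccs1`: in an assay on RBL cells for inhibition of Polyunsaturated fatty acid 5-lipoxygenase (Rattus norvegicus) (on this read-out lower numbers stand for stronger inhibition and higher numbers for weaker inhibition), compound 1 gives 250 nM.
Compound 2, `CC(=O)OCC(=O)N(O)C(C)c1ccc2oc(-c3ccccc3)cc2c1`: in this assay compound 2 gives 160 nM.

Within the data shown here, compound 2 has the lowest of the two numbers, and its only neighbour is compound 1, with a 1.6-fold lower number from compound 1 to compound 2 (0.19 log units; within the scatter); the two are not separated beyond the usual spread.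

Compound 3, `CC(c1ccc2oc(-c3ccccc3)cc2c1)N(O)C(=O)CO`, differs from compound 2 in one place: hydrogen in place of acetyl on an oxygen on a saturated carbon. Among the measured compounds shown here, no measured pair shows the loss of an acetyl from this oxygen. For the measured compounds named here, the single measured step, from compound 1 to compound 2, exchanged the whole group on the carbonyl carbon and stayed within the scatter, so the series so far gives no sign of sensitivity at this end of the molecule. For compound 3 the expectation in this assay is therefore a step of a 1.3-fold higher number from compound 2 to compound 3 (0.10 log units; within the scatter), not beyond the scatter. Compound 3 is estimated at 200 nM, within 80 nM to 500 nM.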

Compound 3, half-maximal inhibitory concentration: 700 nM
Compound 3: middle estimate off by 3.5-fold (0.54 log units), on the low side; the measured number lies above the stated range.
By their numbers in this assay, from the lowest: compounds 2 and 1 (each within the scatter of the next); then compound 3.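

In this assay this end of the molecule proves sensitive to change: hydrogen in place of acetyl on the oxygen gives a 4.4-fold higher number from compound 2 to compound 3 (0.64 log units; beyond the scatter) and hydroxymethyl in place of thiophen-2-yl on the carbonyl carbon gives a 2.8-fold higher number from compound 1 to compound 3 (0.45 log units; beyond the scatter) in the same direction. The group on the carbonyl carbon is therefore not freely exchangeable, since thiophen-2-yl and acetoxymethyl lie within the scatter of each other, while hydroxymethyl stands apart from both with a higher number. Nothing at hand explains this separation.

From the compounds shown here alone, it remains open whether a methoxy group, an amine or a carboxylic acid in place of the hydroxy group would side with compound 2 or with compound 3. Going by these compounds, the effect of a longer chain between the carbonyl carbon and the hydroxy group is also open.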